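Swapping a methoxyphenyl for a furan ring

A few compounds are considered here, and "the series" means these few. Any claim that something is new, unique, unknown or untested is made for them only; others in the source may bear on it.

Compound 1 `COc1ccc(C(C)NC(=O)/N=C(\N)NCCCc2sc(N)nc2C)cc1`: 37.2 nM
Compound 2 `Cc1nc(N)sc1CCCN/C(N)=N/C(=O)NC(c1ccccc1)c1ccccc1`: 43.7 nM
Compound 3 `Cc1nc(N)sc1CCCN/C(N)=N/C(=S)N[C@H](C)c1ccccc1`: 115 nM

All three compounds share the same core and were tested in an assay on membranes from Sf9 cells for displacement of a labelled ligand from histamine H2 receptor (Homo sapiens), read by scintillation counting, with a stated time of 60 min; on this read-out lower numbers stand for stronger inhibition and higher numbers for weaker inhibition. Compound 1 gives the lowest number of the three. Compound 2 lies within the usual scatter of compound 1, so no order between these two can be read from the numbers. Compound 3 sits beyond the scatter, with the clearly higher number of the set.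

Compound 4 `Cc1nc(N)sc1CCCN/C(N)=N/C(=O)NC(C)c1ccco1` has not yet been measured. It differs from compound 1 in one place: furan-2-yl in place of 4-methoxyphenyl on a saturated chain carbon bound to an amide-type nitrogen and a saturated chain carbon. Among the compounds with values here, no pair of measured compounds that differ in exactly one place is available, so the size of this step cannot be read from any measured pair. The expectation is a small step toward a higher number, one that may well stay within the scatter: a 1.6-fold higher number from compound 1 to compound 4 (0.21 log units; within the scatter). Compound 4 is therefore estimated at 60 nM, with a range from 20 nM to 180 nM.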

Compound 4, inhibition constant: 31.6 nM
Beside the measured number, compound 4's estimate is 1.9-fold (0.28 log units) above it; low and high end bracket the measured number.
By their numbers in this assay, from the lowest: compounds 4, 1 and 2 (each within the scatter of the next); then compound 3.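

In this assay, exchanging 4-methoxyphenyl for furan-2-yl on the saturated chain carbon gives a 1.2-fold lower number from compound 1 to compound 4 (0.07 log units; within the scatter) and so the two compounds cannot be told apart. Within the data shown here, this is the first direct reading of a change at this position, which the earlier compounds could not give. Here, a five-membered aromatic ring with one hetero atom and fewer heavy atoms takes the place of a six-membered aromatic ring of carbon only, with no change in the number beyond the scatter.

Going by these compounds, whether this tolerance extends to other groups at this carbon, such as a pyridine ring, an amine or a carboxylic acid, remains open. The data also offer no measurement that explains why the two compounds match.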